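Carbamoyl to dimethylcarbamoyl on the core of compound 1

The source may report more compounds than this note shows. Statements on the series, on what has been measured and on what is new or still open speak of the compounds shown alone.

Three compounds of the series have numbers in an assay for inhibition of Fatty-acid amide hydrolase 1 (Rattus norvegicus); a lower number here means a stronger inhibitor, a higher number a weaker inhibitor. Compound 1 `NC(=O)c1cnc(C(=O)CCc2ccc(Oc3ccccc3)cc2)o1` gives 6.6 nM in this assay. Compound 3 `COC(=O)c1ccc(-c2cnc(C(=O)CCc3ccc(COc4ccccc4)cc3)o2)nc1` gives 3.5 nM in this assay, and compound 2 `CN1CCN(Cc2ccc(-c3ccc(CCC(=O)c4ncc(-c5cccc(C(=O)O)n5)o4)cc3)cc2)CC1` gives 1200 nM. Among these three numbers compound 1 stands second highest; its gap to compound 3 lies within the scatter, so the two cannot be ordered, while its gap to compound 2 lies far beyond the scatter. No pair of these compounds differs in only one place, so no measured step is available to guide the next change.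

Compound 4 `CN(C)C(=O)c1cnc(C(=O)CCc2ccc(Oc3ccccc3)cc2)o1` is the next compound for this assay. It differs from compound 1 in one place: dimethylamino in place of amino on a carbonyl carbon. The change sits on the carbonyl carbon whose other neighbour is the aromatic carbon; cut one bond further out it reads carbamoyl to dimethylcarbamoyl. With no measured step of this kind in the series, the expectation rests on compound 1 alone and carries wide uncertainty. The expected step is a 3.0-fold higher number from compound 1 to compound 4 (0.48 log units; beyond the scatter), modest and toward a higher number. For compound 4 the estimated value in this assay is 20 nM, with a range from 5 nM to 80 nM.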

Compound 4, inhibition constant: 5.4 nM
Estimate against measurement, compound 4: 3.7-fold (0.57 log units) above; low and high end bracket the measured number.
By their numbers in this assay, from the lowest: compounds 3, 4 and 1 (each within the scatter of the next); then compound 2.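

In this assay the first step measured at this position is a 1.2-fold lower number from compound 1 to compound 4 (0.09 log units; within the scatter) and so compound 1 and compound 4 cannot be ordered. On the carbonyl carbon of this core, therefore, amino with its hydrogen-bond donor and the larger dimethylamino without one give numbers that cannot be told apart, which is a first sign that this place accepts the swap, though it rests on this single pair. Nothing measured here accounts for this result.

As far as these compounds go, what stays open is how far this extends on the same carbonyl carbon: whether a larger amine such as diethylamino, piperidine or morpholine would also stay within the scatter of compound 1, or whether a nitrile in place of the whole carbamoyl group would give a clearly different number. From the compounds shown here alone, it is also open whether the swap from carbamoyl to dimethylcarbamoyl would read the same with a different chain on the ketone side of the core, as one pair cannot show whether the result holds elsewhere.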